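A few compounds are considered here, and "the series" means these few. Any claim that something is new, unique, unknown or untested is made for them only; others in the source may bear on it.

Measured so far:
compound 1 `O=C1C[C@H](O)C[C@@H](/C=C/c2c(Cl)cc(Cl)cc2CCc2ccccc2)O1` — 430 nM
compound 2 `CO[C@H]1CC(=O)O[C@H](/C=C/c2c(C)cc(C)cc2-c2ccc(F)c(C)c2)C1` — 106 nM
compound 3 `Cc1cc(-c2cccc(Cl)c2/C=C/[C@@H]2C[C@@H](O)CC(=O)O2)ccc1F` — 30 nM

In an assay for inhibition of 3-hydroxy-3-methylglutaryl-coenzyme A reductase (Rattus norvegicus) (a higher number here means a weaker inhibitor, a lower number a stronger inhibitor), compound 1 gives the highest number of the three; compound 2 lies below it by a gap beyond the scatter, and compound 3 lies further below still. Going by the values given here, compound 4 `Cc1cc(C)cc(-c2cc(Cl)cc(Cl)c2/C=C/[C@@H]2C[C@@H](O)CC(=O)O2)c1` has not yet been measured. 3,5-dimethylphenyl in place of phenethyl on an aromatic carbon Compound 4 thus carries an aromatic ring in place of the phenethyl chain of compound 1, as compounds 2 and 3 also do, and both of those give lower numbers than compound 1; no single-change step connects them, so this is only a loose parallel. A downward step a 6.1-fold lower number from compound 1 to compound 4 (0.79 log units; beyond the scatter) is expected, clearly beyond the scatter. Compound 4 is estimated at 70 nM, within a range from 25 nM to 200 nM.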

Compound 4, half-maximal inhibitory concentration: 13 nM
Compound 4: middle estimate off by 5.4-fold (0.73 log units), on the high side; the measured number lies below the stated range.
By their numbers in this assay, from the lowest: compound 4; then compound 3; then compound 2; then compound 1.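

Going by these compounds alone, at this position, on an aromatic carbon of the core, this assay gives a large change for 3,5-dimethylphenyl in place of phenethyl, a 33-fold lower number from compound 1 to compound 4 (1.52 log units; beyond the scatter), the only step that can be read. The two groups match in every count computed, with the same number of heavy atoms, one aromatic ring and no donors or acceptors, so those counts do not track the difference. No measured evidence accounts for the size of the step.

Going by these compounds, whether a plain phenyl or a longer chain such as 3-phenylpropyl would follow compound 4 or compound 1 stays open. Compound 2 and compound 3 differ from compound 4 in more than one place, so their steps cannot be read.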